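The source may report more compounds than this note shows. Statements on the series, on what has been measured and on what is new or still open speak of the compounds shown alone.

Values in a functional assay on HeLa cells (Homo sapiens) for inhibition; on this read-out lower numbers stand for stronger inhibition and higher numbers for weaker inhibition:
compound 1 `O=C(CC(CC(=O)NC1Cc2ccccc2C1)c1ccc(Cl)cc1)NCCN1CCCCC1` gives 86200 nM
compound 2 `O=C(CC(CC(=O)NC1Cc2ccccc2C1)c1ccc(Cl)cc1)NCCN1CCCC1` gives 77300 nM
compound 3 `CCN(C(=O)CC(CC(=O)NCCN1CCCCC1)c1ccc(Cl)cc1)C1Cc2ccccc2C1` gives 20400 nM
compound 4 `Cc1ccc(C(CC(=O)NCCN2CCCCC2)CC(=O)NC2Cc3ccccc3C2)cc1` is not yet measured

Compound 1 stands level with one neighbour and above the other: the series shows a 1.1-fold lower number from compound 1 to compound 2 (0.05 log units; within the scatter), and also a 4.2-fold lower number from compound 1 to compound 3 (0.63 log units; beyond the scatter). The next step leads to compound 4 and is methyl in place of chloro on an aromatic carbon, para to a large group. Neither measured step changes this group, so the series holds no direct evidence on it, and the two steps give only a general sense of scale. No shift beyond the scatter is expected in this assay. The estimated step is a 1.1-fold lower number from compound 1 to compound 4 (0.03 log units; within the scatter). For compound 4 the expected value is 80000 nM, with an estimated range from 35000 nM to 160000 nM.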

Compound 4, half-maximal inhibitory concentration: > 100000 nM
Compound 4: no number, only a limit (the forecaster's own chance of this, stated with the estimate: 15%); middle value at least 1.2-fold (0.09 log units) from the limit.
By their numbers in this assay, from the lowest: compound 3; then compounds 2 and 1 (each within the scatter of the next). At a limit, above all of these: compound 4.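

In this assay, within the data shown here, 4-chlorophenyl to 4-methylphenyl is the only change at this position, and it gives an at least 1.1-fold higher number from compound 1 to compound 4 (0.06 log units; that floor lies within the scatter). Compound 4 gives > 100000 nM, which is a limit of the assay and not a number. Only a floor can be read for this step, and its true size stays unknown: the limit of > 100000 nM in this assay, at which 1 of the 4 values shown sits.

Open, from the compounds shown here alone, is whether another group at this position, such as methoxy or an amine, would shift the number beyond the scatter. Also open, going by these compounds, is whether the ethyl on the amide-type nitrogen in compound 3 would give a similar step alongside 4-methylphenyl.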